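A few compounds are considered here, and "the series" means these few. Any claim that something is new, unique, unknown or untested is made for them only; others in the source may bear on it.

Measured compounds in an ADME assay for permeability, using PAMPA; on this read-out higher numbers stand for higher permeability and lower numbers for lower permeability:
Compound 1 `C=C(C)C(=O)Nc1cccc(-c2nc3ccccc3s2)c1` gives 987 10^-6 cm/s.
Compound 2 `O=C(O)/C=C/C(=O)Nc1cccc(-c2nc3ccccc3s2)c1` gives 4 10^-6 cm/s.
Compound 3 `CC(C)(CCl)C(=O)Nc1cccc(-c2nc3ccccc3s2)c1` gives 891 10^-6 cm/s.

Compound 2 holds the lowest of the three numbers in this assay, with a 220-fold higher number from compound 2 to compound 3 (2.35 log units; beyond the scatter) and a 250-fold lower number from compound 1 to compound 2 (2.39 log units; beyond the scatter). Compound 4 `O=C(Nc1cccc(-c2nc3ccccc3s2)c1)c1cccnc1Cl` differs from compound 2 by 2-chloropyridin-3-yl in place of 2-carboxyethenyl on a carbonyl carbon. Within the data shown here, two measured steps bear on this change, each of them bringing the 2-carboxyethenyl group into or out of the same place on the carbonyl carbon: a 250-fold lower number from compound 1 to compound 2 (2.39 log units; beyond the scatter) and a 220-fold higher number from compound 2 to compound 3 (2.35 log units; beyond the scatter), both large and beyond the scatter. By contrast, a 1.1-fold lower number from compound 1 to compound 3 (0.04 log units; within the scatter) lies within the scatter. With the 2-carboxyethenyl group likewise removed in compound 4, a large upward step is expected, a 150-fold higher number from compound 2 to compound 4 (2.18 log units; beyond the scatter), in line with a 220-fold higher number from compound 2 to compound 3 (2.35 log units; beyond the scatter), though the entering group is unlike those of compounds 1 and 3. Compound 4 is therefore estimated at 600 10^-6 cm/s, within 250 10^-6 cm/s to 1000 10^-6 cm/s.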

Compound 4, apparent permeability: 677 10^-6 cm/s
Compound 4: middle estimate off by 1.1-fold (0.05 log units), on the low side; measured number inside the range.
By their numbers in this assay, from the lowest: compound 2; then compounds 4, 3 and 1 (each within the scatter of the next).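

In this assay, the first ring on the carbonyl carbon, 2-chloropyridin-3-yl, gives a 170-fold higher number from compound 2 to compound 4 (2.23 log units; beyond the scatter) and joins the high group, with a 1.3-fold lower number from compound 3 to compound 4 (0.12 log units; within the scatter) and a 1.5-fold lower number from compound 1 to compound 4 (0.16 log units; within the scatter) both within the scatter. Three quite different groups in this place thus give numbers that cannot be told apart, and only the 2-carboxyethenyl group of compound 2 stands apart. Nothing measured here explains this. The compounds shown leave open whether a methyl ester of the 2-carboxyethenyl group, or a saturated chain ending in a carboxylic acid, would stay as low as compound 2.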